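This account rests on a few compounds, and the source may have more. Where it says the series, first, only, none or still open, it means among the compounds named here.

In a functional assay on BT-549 cells (Homo sapiens) for cytotoxicity, read by sulforhodamine B assay, with a stated time of 48 h (on this read-out higher numbers stand for weaker inhibition of growth and lower numbers for stronger inhibition of growth), three compounds have been measured so far:

compound 1 `ClCc1cccc(Cn2cnc3c(Cl)ncnc32)c1`, which gives 15100 nM;
compound 2 `ClCc1ccc(Cn2cnc3nc(Cl)nc(Cl)c32)cc1`, which gives 1860 nM;
compound 3 `ClCc1cccc(Cn2cnc3c(Cl)nc(Cl)nc32)c1`, which gives 1690 nM.

Compounds 2 and 3 share the same atoms joined differently, and the difference between their cores is not broken down here; their values lie within the scatter of each other. The informative comparison is between compound 3 and compound 1, which differ in one place, (hydrogen in place of chloro on an aromatic carbon), and this change produced an 8.9-fold higher number from compound 3 to compound 1 (0.95 log units; beyond the scatter).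

Compound 4 `ClCc1ccc(Cn2cnc3ncnc(Cl)c32)cc1` has not yet been measured in this assay. It differs from compound 2 by hydrogen in place of chloro on an aromatic carbon, the same change as from compound 3 to compound 1. Because compound 3 to compound 1 gave an 8.9-fold higher number from compound 3 to compound 1 (0.95 log units; beyond the scatter), and compound 2 gives 1860 nM, a step of similar size is expected here: the estimate for compound 4 is 14000 nM, corresponding to a 7.5-fold higher number from compound 2 to compound 4 (0.88 log units; beyond the scatter), with a range from 5000 nM to 40000 nM. This rests on a single pair, so the expectation is held loosely.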

Compound 4, concentration for 50% growth inhibition: 3710 nM
Compound 4: the middle estimate sits 3.8-fold (0.58 log units) above what was measured; the measured number lies below the stated range.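

In this assay, hydrogen in place of chloro on an aromatic carbon did not give a step of the same size on the two cores: the same change on two cores in this assay, an 8.9-fold higher number (0.95 log units; beyond the scatter) from compound 3 to compound 1 and a 2.0-fold higher number (0.30 log units; within the scatter) from compound 2 to compound 4, 4.5-fold (0.65 log units) apart, beyond the scatter of two such steps. The step now added is a 2.0-fold higher number from compound 2 to compound 4 (0.30 log units; within the scatter), so the two values of that pair cannot be told apart on this read-out, and the larger step on the other core cannot be assumed to carry over. This shows that, among these four compounds, the size of the step differs between the two cores, but with a single pair on each core it does not show why, nor what the change would do on any further core.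

As far as these compounds go, all four compounds carry a chloromethyl group, so it remains open what a plain methyl group or a hydroxymethyl group would give in its place. From the compounds shown here alone, it also remains open how an amine or a methoxy group would compare with chloro or hydrogen on the aromatic carbon at issue.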